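Anilino to benzylamino on a shared amide core

The source may hold more compounds than are shown below. What is called first, only, known or untested is meant among the compounds shown, and "the series" means these compounds.

Within the data shown here, compound 1, `CCCOc1ccc(C(=O)Nc2cccc(CC)n2)cc1`, is the only member of this small set with a numerical reading: in an in vitro assay on HEK-tsA201 cells for antagonist activity at Neuronal acetylcholine receptor; alpha3/beta4 (Homo sapiens), read by fluorescence and calcium flux (on this read-out lower numbers stand for stronger inhibition and higher numbers for weaker inhibition), compound 1 gives 29200 nM. Compound 2, `CCCCCNc1cccc(NC(=O)c2ccc(OCCC)cc2)n1`, carries pentylamino in place of ethyl on an aromatic carbon; in this assay compound 2 reaches only a limit of the assay, > 100000 nM. Compound 3, `CCCOc1ccc(C(=O)Nc2cccc(Nc3ccccc3)n2)cc1`, carries anilino in place of ethyl on an aromatic carbon; in this assay compound 3 likewise stops at a limit, > 100000 nM. Both replacements read as weakening: an at least 3.4-fold higher number from compound 1 to compound 2 (0.53 log units; beyond the scatter) and an at least 3.4-fold higher number from compound 1 to compound 3 (0.53 log units; beyond the scatter). The comparison between the two amino-bearing compounds cannot be read, since a step that the two limits leave unreadable from compound 2 to compound 3; both sit at the limit of > 100000 nM in this assay, at which 2 of the 3 values shown sit. Compound 3 thus stands at the limit, with no number of its own, weaker than compound 1.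

Compound 4, `CCCOc1ccc(C(=O)Nc2cccc(NCc3ccccc3)n2)cc1`, differs from compound 3 by benzyl in place of phenyl on a nitrogen on an aromatic ring. The step from compound 2 to compound 3 is unreadable, and the two steps from compound 1 show only that pentylamino or anilino there gives a reading that stops at a limit. Nothing shown separates a benzyl from a phenyl or a pentyl on this nitrogen, so for compound 4 the expected step is a number no higher from compound 3 to compound 4 (the limit leaves the size open) in this assay, nothing beyond the scatter. Compound 4 is therefore estimated at 100000 nM, within a range from 30000 nM to 300000 nM, most likely once more a limit.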

Compound 4, half-maximal inhibitory concentration: > 100000 nM
Compound 4: no number, only a limit; the forecaster's own chance of this, stated with the estimate: 70%; the middle value sits exactly at the limit.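

In this assay, benzylamino now joins pentylamino and anilino as a replacement for ethyl on this aromatic carbon that gives a weaker reading, with an at least 3.4-fold higher number from compound 1 to compound 4 (0.53 log units; beyond the scatter). Benzyl in place of phenyl on the nitrogen does not bring compound 4 back to a numerical reading, and the steps from compound 2 and from compound 3 to compound 4 cannot be read, so nothing orders these three compounds. Compound 4 gives only a limit, and all the amino-bearing compounds now share that same limit: the limit of > 100000 nM in this assay, at which 3 of the 4 values shown sit.

On these data alone, how far beyond the limit these three compounds lie, and whether they differ from one another at all, stays open. Also open, as far as these compounds go, is whether a plain amine or methylamino on this aromatic carbon, or a methyl or propyl chain in place of ethyl, would give a numerical reading, and how such a reading would compare with that of compound 1.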